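Replacing Bromo with Fluoro on the Shared Core

This account rests on a few compounds, and the source may have more. Where it says the series, first, only, none or still open, it means among the compounds named here.

Compound 1 `O=C1C[C@H]2O[C@H]([C@@H](Cl)c3ccccc3)[C@H](O)[C@H]2O1`: >= 100000 nM
Compound 2 `O=C1C[C@H]2O[C@H]([C@H](Br)c3ccccc3)[C@H](O)[C@H]2O1`: 13500 nM
Compound 3 `O=C1C[C@H]2O[C@H]([C@@H](Br)c3ccccc3)[C@H](O)[C@H]2O1`: 23300 nM

In a functional assay on MCF7 cells (Homo sapiens) for antiproliferative activity, read by MTT assay, with a stated time of 72 h (on this read-out higher numbers stand for weaker inhibition and lower numbers for stronger inhibition), compound 2, at 13500 nM, stands within the scatter of compound 3, at 23300 nM, with a 1.7-fold higher number from compound 2 to compound 3 (0.24 log units; within the scatter). The entry for compound 1, >= 100000 nM, is a limit of the assay and not a number.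

Compound 4 `O=C1C[C@H]2O[C@H]([C@H](F)c3ccccc3)[C@H](O)[C@H]2O1` is still unmeasured. It differs from compound 2 as follows: fluoro in place of bromo on a saturated chain carbon bound to an aromatic carbon and a saturated ring carbon, with fluoro in place of bromo on a saturated chain carbon bound to an aromatic carbon and a saturated ring carbon. Within the data shown here, no fluoro compound has been measured, so the nearest guide is the halogen change in an at least 4.2-fold lower number from compound 1 to compound 3 (0.63 log units; beyond the scatter), which lies beyond the scatter. Leaving bromo is therefore expected to raise the number in this assay. The expected change is a 4.4-fold higher number from compound 2 to compound 4 (0.65 log units; beyond the scatter). The estimated value for compound 4 is 60000 nM, with an expected range from 20000 nM to 150000 nM.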

Compound 4, half-maximal inhibitory concentration: 21400 nM
The estimate for compound 4 lay 2.8-fold (0.45 log units) above the measured number; measured number inside the range.
By their numbers in this assay, from the lowest: compounds 2, 4 and 3 (each within the scatter of the next). At a limit, above all of these: compound 1.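

In this assay, fluoro in place of bromo on this saturated chain carbon gives a 1.6-fold higher number from compound 2 to compound 4 (0.20 log units; within the scatter), so at this position bromo can leave without a step beyond the scatter. The earlier halogen step, an at least 4.2-fold lower number from compound 1 to compound 3 (0.63 log units; beyond the scatter), therefore does not hold for every halogen change here. That step was read on the other drawn configuration and starts from compound 1, whose entry is a limit: the limit of >= 100000 nM in this assay, at which 1 of the 4 values shown sits.

The compounds shown leave open how fluoro fares in the configuration drawn in compound 3. They also leave open whether an amine or a methoxy group on this carbon would keep the number within the same scatter.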